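Fluoro in place of hydrogen: compound 3 to compound 4

This account rests on a few compounds, and the source may have more. Where it says the series, first, only, none or still open, it means among the compounds named here.

Measured in an ADME assay on BJ cells (Homo sapiens) for cytotoxicity, read by luminescence, with a stated time of 72 h (a higher number here means that more compound is needed for the effect, a lower number that less compound is needed), as limits:
compound 1 `CCOC(=O)c1c(-c2cccc(OC)c2)[nH]c2cc(OC)ccc2c1=O` gives > 21500 nM
compound 2 `CCOC(=O)c1c(-c2cccc(-c3ccccc3)c2)[nH]c2cc(OC)c(Cl)cc2c1=O` gives > 21500 nM
compound 3 `CCOC(=O)c1c(-c2cccc(OC)c2)[nH]c2cc(OC)c(Cl)cc2c1=O` gives > 21500 nM

In this assay compound 3 gives > 21500 nM as a limit and not a number. For the measured compounds named here, the series so far shows the limit of > 21500 nM in this assay, at which 3 of the 3 values shown sit, and nothing else. Compound 4 `CCOC(=O)c1c(-c2cc(F)cc(OC)c2)[nH]c2cc(OC)c(Cl)cc2c1=O` differs from compound 3 by fluoro in place of hydrogen on an aromatic carbon with 3-methoxyphenyl going to 3-fluoro-5-methoxyphenyl. Going by the values given here, two measured steps bear on it, a step that the two limits leave unreadable from compound 1 to compound 3 for chloro in place of hydrogen and a step that the two limits leave unreadable from compound 2 to compound 3 for methoxy in place of phenyl. Neither gives a size, so no direction can be read. The expected step is a step that the limit leaves unreadable from compound 3 to compound 4 and none beyond the scatter is foreseen. Compound 4 is expected near 25000 nM with an estimated range from 12000 nM to 45000 nM in this reading.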

Compound 4, half-maximal effective concentration: > 21500 nM
Compound 4: only a limit was reported (the forecaster's own chance of this, stated with the estimate: 85%); the middle value is on the limit's open side.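

No size can be read for the step between compound 3 and compound 4, as both are reported only as limits: the limit of > 21500 nM in this assay, at which 4 of the 4 values shown sit.

The compounds shown leave open what actual value any of compounds 1, 2, 3 and 4 has in this assay, and whether fluoro in place of hydrogen shifts it.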